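Notes on a 4-chloro-3-(trifluoromethyl)phenyl exchange

A few compounds are considered here, and "the series" means these few. Any claim that something is new, unique, unknown or untested is made for them only; others in the source may bear on it.

Measured compounds:
compound 1, `O=C(Nc1cccc(-c2cnc3c(NC(=O)c4cc(Cl)cc(Cl)c4)nccn23)c1)c1ccc(Cl)c(C(F)(F)F)c1`: in a functional assay on NCI-H358 cells (Homo sapiens) for antiproliferative activity, read by CellTiter-Glo, with a stated time of 72 h (on this read-out lower numbers stand for stronger inhibition and higher numbers for weaker inhibition), compound 1 gives 4210 nM
compound 2, `O=C(Nc1cccc(-c2cnc3c(NC(=O)c4cc(Cl)cc(Cl)c4)nccn23)c1)Nc1ccc(F)cc1F`: in this assay compound 2 gives 4170 nM

Compound 2 holds the lower of the two numbers shown, but its nearest neighbour is compound 1 and the gap between them is within the scatter, so no order can be read from it. Going by the values given here, the one measured step, a 1.0-fold lower number from compound 1 to compound 2 (0.00 log units; within the scatter), moved two things at once: the group on the carbonyl carbon and the way it is attached.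

Compound 3, `O=C(Nc1cccc(-c2cnc3c(NC(=O)c4cc(Cl)cc(Cl)c4)nccn23)c1)Nc1ccc(Cl)c(C(F)(F)F)c1`, differs from compound 2 by 4-chloro-3-(trifluoromethyl)phenyl in place of 2,4-difluorophenyl on an amide-type nitrogen. It thus carries the aryl group of compound 1 on the attachment of compound 2. Among the compounds with values here, the single measured step bears on it only indirectly and was flat, so in this assay no step beyond the scatter is expected in either direction. For compound 3 the expected step of a 1.0-fold lower number from compound 2 to compound 3 (0.02 log units; within the scatter) is therefore flat, and compound 3 is estimated at 4000 nM, with a range from 1500 nM to 11000 nM.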

Compound 3, half-maximal inhibitory concentration: 8580 nM
Compound 3: middle estimate off by 2.1-fold (0.33 log units), on the low side; low and high end bracket the measured number.
By their numbers in this assay, from the lowest: compounds 2 and 1 (each within the scatter of the next); then compound 3.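

In this assay the aryl group on the amide-type nitrogen does register: 4-chloro-3-(trifluoromethyl)phenyl in place of 2,4-difluorophenyl gives a 2.1-fold higher number from compound 2 to compound 3 (0.31 log units; beyond the scatter), a modest step. With 4-chloro-3-(trifluoromethyl)phenyl held constant, the amino link on the carbonyl carbon gives a 2.0-fold higher number from compound 1 to compound 3 (0.31 log units; beyond the scatter), so the flat step from compound 1 to compound 2 now reads as two modest changes that offset each other. No measurement shown accounts for either step.

As far as these compounds go, whether the amino link has a similar effect with 2,4-difluorophenyl remains open, as that group set directly on the carbonyl carbon would be needed to test it. Also open, from the compounds shown here alone, is how an unsubstituted phenyl, a pyridine ring or a cyclohexyl group on the amide-type nitrogen would compare.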